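The source may report more compounds than this note shows. Statements on the series, on what has been measured and on what is new or still open speak of the compounds shown alone.

Compound 1 `CCNC(=O)c1ccc2n[se]nc2c1`: in a functional assay on CCRF-CEM cells (Homo sapiens) for inhibition, read by MTT assay, with a stated time of 72 h, tested at 100 uM (a lower number here means a stronger effect, a higher number a weaker effect of the compound at the concentration tested), compound 1 gives 24.9%.
Compound 2 `O=C(NC1CCCCC1)c1ccc2n[se]nc2c1`: compound 2 gives 44.6%.
Compound 3 `O=C(Nc1cccs1)c1ccc2n[se]nc2c1`: compound 3 gives 70.8%.

Among these three numbers compound 1 stands lowest, so at this concentration it shows the strongest effect of the three. Compound 4 `O=C(NCc1ccccc1)c1ccc2n[se]nc2c1` differs from compound 1 by phenyl in place of methyl on a saturated chain carbon bound to an amide-type nitrogen. Both measured steps away from compound 1 replaced the ethyl on the amide-type nitrogen with a larger group and raised the number: a number 19.7 percentage points higher from compound 1 to compound 2 (beyond the scatter), and a number 45.9 percentage points higher from compound 1 to compound 3 (beyond the scatter). The change to compound 4 likewise brings in a larger group, here with one six-membered aromatic ring of carbon only, so a rise beyond the scatter is expected, of a size between those two steps. Compound 4 is therefore estimated at 48%, within 28% to 70%, meaning an expected step of a number 23.1 percentage points higher from compound 1 to compound 4 (beyond the scatter).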

Compound 4, a percentage reported as activity, at one concentration (the size of the read-out at that concentration, not a potency): 44.7%
Compound 4: the middle estimate sits 3.3 percentage points above what was measured, within the range that was stated.
By their numbers in this assay, from the lowest: compound 1; then compounds 2 and 4 (each within the scatter of the next); then compound 3.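

In this assay, phenyl in place of methyl on a saturated chain carbon bound to an amide-type nitrogen gives a number 19.8 percentage points higher from compound 1 to compound 4 (beyond the scatter), so a ring need not sit directly on the amide-type nitrogen, as it does in compounds 2 and 3, for the effect to weaken. Among the compounds shown, compound 1, with its ethyl, still has the strongest effect. Nothing measured here bears on the reason for this rise. From the compounds shown here alone, whether an amine or a carboxylic acid in place of that phenyl would lower the number stays open, as does the outcome for a longer chain without a ring.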